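The source may hold more compounds than are shown below. What is called first, only, known or untested is meant among the compounds shown, and "the series" means these compounds.

Measured so far: compound 1 `COc1cc(OC)c(C(=O)/C=C/c2ccccc2SC)c(OC)c1` gives 37% in a functional assay on Huh-7 cells (Homo sapiens), read by fluorescence and BrdU incorporation, with a stated time of 48 h, tested at 10 uM; a lower number here means a stronger effect, a higher number a weaker effect of the compound at the concentration tested; compound 2 `COc1cc(OC)c(C(=O)/C=C/c2ccc(Cl)cc2)c(OC)c1` gives 33% in this assay.

Compound 2 stands at the lowest of the two numbers, but its nearest neighbour is compound 1, and the gap a number 4 percentage points lower from compound 1 to compound 2 (within the scatter) lies within the scatter, so the two compounds cannot be told apart on these data. Compound 3 `COc1cc(OC)c(C(=O)/C=C/c2ccc(Br)cc2)c(OC)c1` has not yet been measured. It differs from compound 2 in one place: bromo in place of chloro on an aromatic carbon on a six-membered aromatic ring of carbon only, para to a large group.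

Among the measured compounds shown here, no measured step covers a change from chloro to bromo, so the only guidance is indirect. For the measured compounds named here, the single step available, a number 4 percentage points lower from compound 1 to compound 2 (within the scatter), replaced one substituted phenyl group by another and left the number within the scatter. A swap of one halogen for the neighbouring one at the same place is a smaller change than that, so no step beyond the scatter is expected in this assay, in either direction. The expected step of a number 1 percentage points lower from compound 2 to compound 3 (within the scatter) is essentially flat. Compound 3 is therefore estimated at 32%, with a range from 18% to 46%.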

Compound 3, a percentage reported as activity, at one concentration (the size of the read-out at that concentration, not a potency): 46%
For compound 3 the middle estimate is 14 percentage points below the measured one; the measured number falls inside the stated range.
By their numbers in this assay, from the lowest: compounds 2, 1 and 3 (each within the scatter of the next, the first and the last beyond it).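

At this place on the aromatic ring, para to a large group, swapping one halogen for another is not a silent change: in this assay bromo in place of chloro gives a number 13 percentage points higher from compound 2 to compound 3 (beyond the scatter) and so a weaker effect at the concentration tested, even though only one heavy atom differs and no ring, hydrogen-bond donor, hydrogen-bond acceptor or charge enters or leaves. Among the compounds shown here, this is the first step to lie beyond the scatter, and its size is modest. Replacing the whole 2-(methylsulfanyl)phenyl group by 4-bromophenyl gives a number 9 percentage points higher from compound 1 to compound 3 (within the scatter) and so stays within the scatter, which shows that in this small set a small structural change can produce the larger step in the read-out. Nothing available here accounts for the difference between chloro and bromo.

Only two halogens are shown at this place, so it remains open how fluoro, iodo, an amine or a carboxylic acid there would behave. From the compounds shown here alone, each read-out is also taken at a single concentration and is not a potency, so it remains open whether the step between chloro and bromo would persist across a range of concentrations.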